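A few compounds are considered here, and "the series" means these few. Any claim that something is new, unique, unknown or untested is made for them only; others in the source may bear on it.

Measured in a functional assay on NAMALVA cells (Homo sapiens) for cytotoxicity, read by MTT assay, with a stated time of 72 h; on this read-out lower numbers stand for stronger inhibition and higher numbers for weaker inhibition:
Compound 1 `O=C(Nc1ccc(C(=O)NO)cc1)Nc1ccc([N+](=O)[O-])cc1`: 13300 nM
Compound 2 `O=C(/C=C/c1ccc(NC(=O)Nc2ccccc2)cc1)NO`: 300 nM
Compound 3 `COc1ccc(NC(=O)Nc2ccc(/C=C/C(=O)NO)cc2)cc1`: 460 nM

Compound 3, at 460 nM, lies within the scatter of compound 2, at 300 nM. Compound 1 stands well apart from both with the much higher number of 13300 nM.

Compound 4 `O=C(/C=C/c1ccc(NC(=O)Nc2ccc([N+](=O)[O-])cc2)cc1)NO` has not yet been measured. It differs from compound 3 by one change, nitro in place of methoxy on an aromatic carbon, para to a large group: nitro in place of methoxy on an aromatic carbon.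

For the measured compounds named here, only one measured step bears directly on this carbon: a 1.5-fold higher number from compound 2 to compound 3 (0.19 log units; within the scatter), which is methoxy in place of hydrogen and stays within the scatter. Compound 1 also carries a nitro group, but it differs from compound 4 elsewhere in its structure, so compound 1 with its value of 13300 nM does not measure this change. Going by the values given here, no measured pair compares nitro with hydrogen or methoxy directly, so the evidence is thin.

With only the small step seen from a 1.5-fold higher number from compound 2 to compound 3 (0.19 log units; within the scatter) as a guide, no step beyond the scatter is expected in this assay, and no direction is favoured. The expected step is a 1.0-fold lower number from compound 3 to compound 4 (0.01 log units; within the scatter). For compound 4 the estimated value is 450 nM, with an expected range from 150 nM to 1400 nM.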

Compound 4, half-maximal inhibitory concentration: 580 nM
For compound 4 the middle estimate is 1.3-fold (0.11 log units) below the measured one; the range from low to high includes it.
By their numbers in this assay, from the lowest: compounds 2, 3 and 4 (each within the scatter of the next); then compound 1.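

In this assay, nitro on this aromatic carbon, para to a large group, now has a direct comparison with both neighbouring substituents: nitro in place of methoxy gives a 1.3-fold higher number from compound 3 to compound 4 (0.10 log units; within the scatter), and nitro in place of hydrogen gives a 1.9-fold higher number from compound 2 to compound 4 (0.29 log units; within the scatter), so hydrogen, methoxy and nitro cannot be told apart here by these numbers. The result also gives compound 1 its first partner differing in only one place: with the nitro group held constant, 2-(hydroxycarbamoyl)ethenyl in place of hydroxycarbamoyl on an aromatic carbon gives a 23-fold lower number from compound 1 to compound 4 (1.36 log units; beyond the scatter), which ties the large gap to that change at the other end of the molecule and not to the nitro group. Nothing in the available data explains either the flat response at the nitro position or the large step at the other position.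

On these data alone, it remains open whether an amine or a carboxylic acid on the same carbon would also stay within the scatter of these three compounds. As far as these compounds go, it is equally open whether a longer chain in place of 2-(hydroxycarbamoyl)ethenyl would move the number further, and whether that large step would recur with hydrogen or methoxy in place of nitro.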